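Compound 2 to compound 3: swapping a side chain

This account rests on a few compounds, and the source may have more. Where it says the series, first, only, none or still open, it means among the compounds named here.

Compound 1 `CCn1c(C(=O)NCC(OC)OC)ccc1C(CC)(CC)c1ccc(OCC(O)C(C)(C)C)c(C)c1` gives > 50000 nM as a limit of the assay
Compound 2 `CCn1c(C(=O)NCCN)ccc1C(CC)(CC)c1ccc(OCC(O)C(C)(C)C)c(C)c1` gives 5.9 nM as a measured number

Going by the values given here, both were tested in a functional assay on MCF7 cells (Homo sapiens), read by MTT assay, with a stated time of 48 h (on this read-out lower numbers stand for stronger inhibition and higher numbers for weaker inhibition), and compound 2 holds the only actual number there (5.9 nM). Compound 3 `CCn1c(C(=O)N(C)CCC#N)ccc1C(CC)(CC)c1ccc(OCC(O)C(C)(C)C)c(C)c1` has not been measured yet. It differs from compound 2 on a carbonyl carbon, where (2-cyanoethyl)(methyl)amino stands in place of (2-aminoethyl)amino ((2-cyanoethyl)(methyl)amino in place of (2-aminoethyl)amino on a carbonyl carbon). Among the compounds with values here, one measured step bears on this change, with aminomethyl in place of dimethoxymethyl, and one end of it is a limit (the limit of > 50000 nM in this assay, at which 1 of the 2 values shown sits). Compound 3 also lacks that aminomethyl, so going by this large step beyond the scatter (an at least 8400-fold lower number from compound 1 to compound 2 (3.92 log units; beyond the scatter)) a large move towards weaker inhibition is expected in this assay here too. The expected step is large (a 1700-fold higher number from compound 2 to compound 3 (3.23 log units; beyond the scatter)). Compound 3 is estimated at 10000 nM (expected range 200 nM to 80000 nM).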

Compound 3, half-maximal inhibitory concentration: > 50000 nM
Compound 3 gave a limit, no number; the forecaster's own chance of this, stated with the estimate: 45%; middle value at least 5.0-fold (0.69 log units) away from the limit.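

Replacing (2-aminoethyl)amino on the carbonyl carbon with (2-cyanoethyl)(methyl)amino gives an at least 8400-fold higher number from compound 2 to compound 3 (3.92 log units; beyond the scatter), so a second, quite different replacement of this side chain also ends far from the potency of compound 2. This single swap changes several things at once: the amine goes, a nitrile comes in and the hydrogen-bond donors are lost, so the step cannot be pinned on any one of them. Compound 1 and compound 3 cannot be ranked, and the step between them cannot be read, because both are limits rather than numbers: the limit of > 50000 nM in this assay, at which 2 of the 3 values shown sit.

Whether the amine alone accounts for the large step stays open. A (3-aminopropyl)amino or a [2-(dimethylamino)ethyl]amino group on the same carbonyl carbon would help to separate the amine from the rest of the chain.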